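The compounds below may be only part of what the source reports. "The series", "measured", "known", "first", "only" and "open" are said of these compounds alone.

Working notes on the series. The shared core appears in compound 1 `CCCS(=O)(=O)Nc1cccc2c1CCCC2c1c[nH]cn1`, compound 2 `O=S(=O)(Nc1cccc2c1CCCC2c1c[nH]cn1)C1CC1` and compound 3 `O=S(=O)(Nc1cccc2c1CCCC2c1c[nH]cn1)c1ccc2ccccc2c1`. In an assay on isolated protein (Cricetulus griseus) for binding affinity to Alpha-1B adrenergic receptor (Mesocricetus auratus), read by radioligand binding (on this read-out higher numbers stand for weaker inhibition and lower numbers for stronger inhibition), compound 1 gives only a limit, < 10000 nM. In this assay compound 2 likewise gives only a limit, < 10000 nM. In this assay compound 3 gives 214 nM. The step that the two limits leave unreadable from compound 1 to compound 2 stays unreadable because of the limit of < 10000 nM in this assay, at which 2 of the 3 values shown sit. Compound 4 `COC(=O)Nc1cccc2c1CCCC2c1c[nH]cn1` differs from compound 2 by methoxycarbonyl in place of cyclopropylsulfonyl on a nitrogen on an aromatic ring. Among the compounds with values here, no measured step bears on this change; the one step, from compound 1 to compound 2, gives neither size nor direction, so nothing beyond the scatter can be expected with confidence. For compound 4 in this assay the estimate is 6000 nM, with a range of 1000 nM to 30000 nM. That estimate is expected to mean a step that the limit leaves unreadable from compound 2 to compound 4, and a further limit is the likelier outcome.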

Compound 4, inhibition constant: 10000 nM
Beside the measured number, compound 4's estimate is 1.7-fold (0.22 log units) below it, and the stated range covers the measured number.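

In this assay, within the data shown here, compound 4 gives 10000 nM, the first plain number for a group other than a sulfonyl on this nitrogen. Compound 1 and compound 2 give only limits of the assay, not numbers. The new value is a number no lower from compound 2 to compound 4 (the limit leaves the size open), and likewise a number no lower from compound 1 to compound 4 (the limit leaves the size open). The size of neither step can be read: the limit of < 10000 nM in this assay, at which 2 of the 4 values shown sit.

Still open, as far as these compounds go, is what an acetyl group or a urea on this nitrogen would give. Also open, from the compounds shown here alone, is how a benzyloxycarbonyl group would read against the methoxycarbonyl of compound 4.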